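Cytotoxicity notes on the shared core: compound 3 to compound 4

The source may hold more compounds than are shown below. What is called first, only, known or untested is meant among the compounds shown, and "the series" means these compounds.

Compound 1 `Nc1nc(-c2ccc(F)cc2)cc(-c2ccc(C3NC(=O)c4ccccc4N3)cc2)n1`: "not determined" (no result reported)
Compound 2 `Nc1nc(-c2ccc(Br)cc2)cc(-c2ccc(C3NC(=O)c4ccccc4N3)cc2)n1`: > 400000 nM
Compound 3 `COc1cccc(-c2cc(-c3ccc(C4NC(=O)c5ccccc5N4)cc3)nc(N)n2)c1OC`: > 400000 nM

In an ADME assay on Vero cells (Chlorocebus sabaeus) for cytotoxicity, read by MTT assay, with a stated time of 72 h (a lower number here means that less compound is tolerated, a higher number that more compound is tolerated), compound 1 gives "not determined" (no result reported). Compound 2 sits at a limit of the assay, > 400000 nM. Compound 3 likewise sits at a limit, > 400000 nM, so its standing is a limit rather than a number, as is one further value shown, while compound 1 has no number at all. Among the measured compounds shown here, the only measured step, a step that the two limits leave unreadable from compound 2 to compound 3, is therefore unreadable in size. Compound 4 `Nc1nc(-c2ccc(Cl)cc2)cc(-c2ccc(C3NC(=O)c4ccccc4N3)cc2)n1` differs from compound 3 by 4-chlorophenyl in place of 2,3-dimethoxyphenyl on an aromatic carbon. For the measured compounds named here, no measured step bears readably on this change; two of the three values sit at the same limit (the limit of > 400000 nM in this assay, at which 2 of the 3 values shown sit). The expectation is no step beyond the scatter, a number no higher from compound 3 to compound 4 (the limit leaves the size open), with compound 4 most likely again reported only as a limit. Compound 4 is estimated at 400000 nM, range 200000 nM to 800000 nM.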

Compound 4, half-maximal cytotoxic concentration: 323000 nM
Beside the measured number, compound 4's estimate is 1.2-fold (0.09 log units) above it; the measured number falls inside the stated range.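

In this assay compound 4 is the only compound shown with a number rather than a limit, which gives this aromatic carbon its first readable anchor. The change to 4-chlorophenyl gives an at least 1.2-fold lower number from compound 3 to compound 4 (0.09 log units; that floor lies within the scatter), and chloro in place of bromo gives an at least 1.2-fold lower number from compound 2 to compound 4 (0.09 log units; that floor lies within the scatter). Both steps rest on a limit on one side: the limit of > 400000 nM in this assay, at which 2 of the 4 values shown sit.

On these data alone, how far compound 2 and compound 3 truly lie from compound 4 stays open. Also open, as far as these compounds go, is what an amine or a carboxylic acid on this phenyl ring would do to the number.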